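Terphenyl Benzimidazoles: Same Change, New Hydroxy Core

The source may hold more compounds than are shown below. What is called first, only, known or untested is meant among the compounds shown, and "the series" means these compounds.

Measured compounds:
compound 1 `CN(C)c1ccc(-c2ccc(-c3ccc(-c4nc5ccccc5[nH]4)cc3)cc2)cc1`: 39300 nM
compound 2 `Clc1cccc(-c2ccc(-c3ccc(-c4nc5ccccc5[nH]4)cc3)cc2)c1`: 32300 nM
compound 3 `CN(C)c1ccc(-c2ccc(-c3ccc(-c4nc5c(O)cccc5[nH]4)cc3)cc2)cc1`: 4200 nM

In a functional assay on KB cells (Homo sapiens) for inhibition, read by sulforhodamine B assay (on this read-out higher numbers stand for weaker inhibition of growth and lower numbers for stronger inhibition of growth), compound 1 gives 39300 nM, compound 2 gives 32300 nM and compound 3 gives 4200 nM. The change 3-chlorophenyl in place of 4-(dimethylamino)phenyl on an aromatic carbon made a step of a 1.2-fold lower number from compound 1 to compound 2 (0.09 log units; within the scatter). The cores of compound 1 and compound 3 differ by hydroxy in place of hydrogen on an aromatic carbon, a step of a 9.4-fold lower number from compound 1 to compound 3 (0.97 log units; beyond the scatter). Compound 4 `Oc1cccc2[nH]c(-c3ccc(-c4ccc(-c5cccc(Cl)c5)cc4)cc3)nc12` is not yet measured; it differs from compound 3 by 3-chlorophenyl in place of 4-(dimethylamino)phenyl on an aromatic carbon, the same change that separates compound 2 from compound 1, at a place described in identical words. The expectation rests on the earlier step of a 1.2-fold lower number from compound 1 to compound 2 (0.09 log units; within the scatter), which lay within the scatter. Compound 4 is therefore expected to give 3500 nM, within an estimated range of 1500 nM to 8000 nM. For compound 4 this amounts to an expected step of a 1.2-fold lower number from compound 3 to compound 4 (0.08 log units; within the scatter).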

Compound 4, concentration for 50% growth inhibition: 2280 nM
Compound 4: middle estimate off by 1.5-fold (0.19 log units), on the high side; the range from low to high includes it.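

On the core carrying the hydroxy, 3-chlorophenyl in place of 4-(dimethylamino)phenyl gave a 1.8-fold lower number from compound 3 to compound 4 (0.27 log units; within the scatter) in this assay, and this change carried over between the two cores without a difference that can be told from scatter: the same change on two cores in this assay, a 1.2-fold lower number (0.09 log units; within the scatter) from compound 1 to compound 2 and a 1.8-fold lower number (0.27 log units; within the scatter) from compound 3 to compound 4, 1.5-fold (0.18 log units) apart, within the scatter of two such steps

The hydroxy change also held with 3-chlorophenyl in place, giving a 14-fold lower number from compound 2 to compound 4 (1.15 log units; beyond the scatter), and it matched its size on the other core: the same change on two cores in this assay, a 9.4-fold lower number (0.97 log units; beyond the scatter) from compound 1 to compound 3 and a 14-fold lower number (1.15 log units; beyond the scatter) from compound 2 to compound 4, 1.5-fold (0.18 log units) apart, within the scatter of two such steps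

This shows that the two changes combined consistently across these four compounds, but it rests on one pair of groups and two cores, and it does not show that the aryl exchange itself has any effect on growth inhibition.

The compounds shown leave open whether this agreement would hold with an amine or a carboxylic acid in place of 3-chlorophenyl. They also leave open whether a methoxy group in place of the hydroxy would carry over in the same way.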